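Amino for nitro on a compound at the limit

The source may report more compounds than this note shows. Statements on the series, on what has been measured and on what is new or still open speak of the compounds shown alone.

In a functional assay on Malme-3M cells (Homo sapiens) for cytotoxicity, read by MTT assay, with a stated time of 6 days (on this read-out higher numbers stand for an effect only at larger amounts of compound and lower numbers for an effect already at smaller amounts), compound 1 (`COC(=O)c1c(-c2ccc(OC)cc2)oc2ccccc2c1=O`) gives > 25 ug/mL (a limit of the assay, not a number). Compound 2 (`O=c1cc(-c2ccc([N+](=O)[O-])cc2)oc2cc(O)ccc12`) gives > 25 ug/mL (likewise a limit, not a number). Compound 3 (`O=c1cc(-c2ccc([N+](=O)[O-])cc2)oc2c(O)c(O)ccc12`) gives a true number (3.61 ug/mL). Compound 2 thus stands at the limit of > 25 ug/mL in this assay, at which 2 of the 3 values shown sit, and offers no exact starting value.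

Compound 4 (`Nc1ccc(-c2cc(=O)c3ccc(O)cc3o2)cc1`) carries amino in place of nitro on an aromatic carbon. This sits on a six-membered aromatic ring of carbon only, para to a large group.

Within the data shown here, only one measured step is available (an at least 6.9-fold lower number from compound 2 to compound 3 (0.84 log units; beyond the scatter)). That step is beyond the scatter, but it is hydroxy in place of hydrogen on an aromatic carbon, with the nitro kept. Among the measured compounds shown here, no measured step changes the nitro, so the size of the step from compound 2 to compound 3 serves only as a loose guide. A change in this assay towards lower numbers is expected to be smaller than that step, and it may stay within the scatter.

The expected step is small and remains an estimate (an at least 1.2-fold lower number from compound 2 to compound 4 (0.09 log units; that floor lies within the scatter)). For compound 4 the estimated value is 20 ug/mL (expected range 7 ug/mL to 40 ug/mL), and a reading at the limit is about as likely as a number.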

Compound 4, concentration for half-maximal effect: > 25 ug/mL
Compound 4 was reported as a limit; the forecaster's own chance of this, stated with the estimate: 50%; at least 1.2-fold (0.09 log units) between middle value and limit.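

Compound 2 and compound 4 both give a limit rather than a number, so the step between them cannot be read: the limit of > 25 ug/mL in this assay, at which 3 of the 4 values shown sit.

The compounds shown leave open whether amino in place of nitro changes the read-out at all, and whether hydroxy in place of hydrogen on an aromatic carbon would give a similar step with the amino present.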